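Furan-2-yl Ester in Place of the Pyridin-4-yl Ester

This account rests on a few compounds, and the source may have more. Where it says the series, first, only, none or still open, it means among the compounds named here.

Compound 1, `CC1=CC[C@H]2[C@H](CC[C@]2(C)O)C(C)(C)[C@@H]1CC[C@H]1[C@]2(C)CC[C@H](OC(=O)c3ccncc3)C(C)(C)O[C@H]2CC[C@@]1(C)O`, in a functional assay on MDA-MB-231 cells (Homo sapiens) for antiproliferative activity, read by MTT assay, with a stated time of 72 h (a higher number here means a weaker inhibitor, a lower number a stronger inhibitor), gives 18000 nM.
Compound 2, `CC1=CC[C@H]2[C@@H]1CC=C(C)[C@@H](CC[C@H]1[C@]3(C)CC[C@H](OCc4ccccc4)C(C)(C)O[C@H]3CC[C@@]1(C)O)C2(C)C`, in this assay gives 35700 nM.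

The two measured numbers lie within the usual scatter of each other, so neither compound can be called the stronger inhibitor; compound 1 simply carries the lower figure of the pair. The unmeasured compound 3, `CC1=CC[C@H]2[C@H](CC[C@]2(C)O)C(C)(C)[C@@H]1CC[C@H]1[C@]2(C)CC[C@H](OC(=O)c3ccco3)C(C)(C)O[C@H]2CC[C@@]1(C)O`, differs from compound 1 in one place: furan-2-yl in place of pyridin-4-yl on a carbonyl carbon. Within the data shown here, no measured pair speaks to such an exchange, so the step of a 1.1-fold higher number from compound 1 to compound 3 (0.05 log units; within the scatter) is expected to stay within the scatter, in no set direction. Compound 3 is therefore estimated at 20000 nM, with a range from 8000 nM to 50000 nM.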

Compound 3, half-maximal inhibitory concentration: 14000 nM
Estimate against measurement, compound 3: 1.4-fold (0.15 log units) above; low and high end bracket the measured number.
By their numbers in this assay, from the lowest: compounds 3, 1 and 2 (each within the scatter of the next, the first and the last beyond it).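

The step in this assay is a 1.3-fold lower number from compound 1 to compound 3 (0.11 log units; within the scatter) and so this single pair shows that, on this carbonyl carbon, a five-membered aromatic ring with an oxygen can replace a six-membered aromatic ring with a nitrogen without a readable difference. No measurement at hand offers an explanation for this result. The compounds shown leave open whether an aromatic ring is needed on the carbonyl carbon at all. A saturated cyclohexyl group, a plain methyl group or a chain ending in an amine could each give a different answer.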